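Nitro in place of fluoro: what to expect

This account rests on a few compounds, and the source may have more. Where it says the series, first, only, none or still open, it means among the compounds named here.

Measured in a functional assay on MCF7 cells (Homo sapiens) for antiproliferative activity, read by MTT assay, with a stated time of 72 h; on this read-out lower numbers stand for stronger inhibition and higher numbers for weaker inhibition:
compound 1 `COc1ccc(/C=C2/CN(C)/C(=N/c3ccc(OC)cc3)S2)cc1`: 8700 nM
compound 2 `COc1ccc(/C=C2/CN(C)/C(=N/c3ccc(F)cc3)S2)cc1`: 8000 nM

Among the compounds with values here, compound 2, at 8000 nM, cannot be told apart from compound 1, the only other measured compound, as the two values lie within the scatter of each other. The next compound, compound 3 `COc1ccc(/C=C2/CN(C)/C(=N/c3ccc([N+](=O)[O-])cc3)S2)cc1`, keeps the shared core and changes a single group: nitro in place of fluoro on an aromatic carbon. Nitro thus takes the place of fluoro on an aromatic carbon, para to a large group.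

Within the data shown here, only one measured step bears on this change, and it concerns the same aromatic carbon: a 1.1-fold lower number from compound 1 to compound 2 (0.04 log units; within the scatter). There, fluoro in place of methoxy left the number within the scatter. Among the measured compounds shown here, this is thin evidence, since it is a single step and no measured compound carries nitro, so a larger move in either direction cannot be ruled out. In this assay, no change beyond the scatter is expected, and the estimated step is no change at the digits printed from compound 2 to compound 3 (within the scatter). For compound 3 the estimated value is 8000 nM, with an expected range from 3200 nM to 20000 nM.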

Compound 3, half-maximal inhibitory concentration: 9800 nM
Estimate against measurement, compound 3: 1.2-fold (0.09 log units) below; the measured number falls inside the stated range.
By their numbers in this assay, from the lowest: compounds 2, 1 and 3 (each within the scatter of the next).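

In this assay, within the data shown here, this aromatic carbon, para to a large group, has now carried three different groups: nitro in place of fluoro gives a 1.2-fold higher number from compound 2 to compound 3 (0.09 log units; within the scatter) and nitro in place of methoxy gives a 1.1-fold higher number from compound 1 to compound 3 (0.05 log units; within the scatter) so no step among the three compounds leaves the scatter. The earlier compounds shown here offered only the exchange of methoxy for fluoro, whereas compound 3 brings in a group of three heavy atoms with two hydrogen-bond acceptors in place of a single fluorine atom with none, and even this difference in the counts goes with no step beyond the scatter. No measurement shown here gives a reason for this flat result.

From the compounds shown here alone, what remains open is whether any group on this carbon can move the number beyond the scatter, as an amine, a carboxylic acid or a longer chain might or might not do. All the steps shown fall on this one carbon, so the effect of a change elsewhere on the shared core remains unknown.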